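Swapping trifluoromethoxy for ethoxy on compound 3

A few compounds are considered here, and "the series" means these few. Any claim that something is new, unique, unknown or untested is made for them only; others in the source may bear on it.

In a functional assay on HepG2 cells (Homo sapiens) for antiproliferative activity, read by MTT assay, with a stated time of 48 h (on this read-out lower numbers stand for stronger inhibition and higher numbers for weaker inhibition), compound 1 `CCn1c(C(=O)NCCN(C)C)ccc1C(CC)(CC)c1ccc(OCCC(O)(CC)CC)c(C)c1` gives 240 nM. Compound 2 `CCn1c(C(=O)N(CCC#N)CCC#N)ccc1C(CC)(CC)c1ccc(OCCC(O)(CC)CC)c(C)c1` gives 46300 nM, which is a 190-fold higher number from compound 1 to compound 2 (2.29 log units; beyond the scatter).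

Compound 3 `CCn1c(C(=O)Nc2ccc(OC(F)(F)F)cc2)ccc1C(CC)(CC)c1ccc(OCCC(O)(CC)CC)c(C)c1` has no exact number, only a limit of the assay, > 50000 nM. Among the measured compounds shown here, it is the one compound standing at the limit of > 50000 nM in this assay, at which 1 of the 3 values shown sits. Putting 4-(trifluoromethoxy)phenyl in place of 2-(dimethylamino)ethyl on the amide-type nitrogen gives an at least 200-fold higher number from compound 1 to compound 3 (2.31 log units; beyond the scatter). Compounds 2 and 3 cannot be separated, with an at least 1.0-fold higher number from compound 2 to compound 3 (0.03 log units; that floor lies within the scatter).

Compound 4 `CCOc1ccc(NC(=O)c2ccc(C(CC)(CC)c3ccc(OCCC(O)(CC)CC)c(C)c3)n2CC)cc1` differs from compound 3 by one small change (ethyl in place of trifluoromethyl on an oxygen on an aromatic ring), turning trifluoromethoxy into ethoxy. For the measured compounds named here, no measured step tests this swap directly, since the large steps above replace the whole group on the carbonyl carbon. The aromatic amide stays, so the weak standing of compound 3 at > 50000 nM is expected to carry over, with no change beyond the scatter. The expected result is an at least 1.2-fold lower number from compound 3 to compound 4 (0.09 log units; that floor lies within the scatter). For compound 4, the estimate in this assay is 40000 nM, within a range of 10000 nM to 50000 nM.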

Compound 4, half-maximal inhibitory concentration: > 50000 nM
Compound 4 was reported as a limit (the forecaster's own chance of this, stated with the estimate: 55%); middle value at least 1.2-fold (0.09 log units) from the limit.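

In this assay, compound 4 gives only a limit of the assay, > 50000 nM. The step between compound 3 and compound 4 cannot be read, but it is now clear that putting ethyl in place of trifluoromethyl on this oxygen does not bring the compound off that limit: the limit of > 50000 nM in this assay, at which 2 of the 4 values shown sit. Putting 4-ethoxyphenyl in place of 2-(dimethylamino)ethyl on the amide-type nitrogen gives an at least 200-fold higher number from compound 1 to compound 4 (2.31 log units; beyond the scatter), while the change on the carbonyl carbon gives an at least 1.0-fold higher number from compound 2 to compound 4 (0.03 log units; that floor lies within the scatter), so these two compounds cannot be separated.

Any true difference between ethoxy and trifluoromethoxy stays hidden past the limit. Going by these compounds, it remains open whether a longer chain in place of ethyl on this oxygen, or an amine at the end of such a chain, would give a measurable number.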